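This account rests on a few compounds, and the source may have more. Where it says the series, first, only, none or still open, it means among the compounds named here.

Values in a physicochemical assay for permeability, using PAMPA (on this read-out lower numbers stand for lower permeability and higher numbers for higher permeability), as follows:
Compound 1 `C[C@@H](Oc1cc2oc(=O)n(CCC(=O)O)c2cc1Cl)c1cccnn1` gives < 3 nm/s as a limit
Compound 2 `C[C@@H](Oc1cc2oc(=O)n(CCC(=O)O)c2cc1Cl)c1ncccn1` gives < 3 nm/s as a limit

Compound 2 stands at a limit and not at a number. Going by the values given here, the series so far shows the limit of < 3 nm/s in this assay, at which 2 of the 2 values shown sit, and no readable value. Compound 3 `Cc1cccc([C@@H](C)Oc2cc3oc(=O)n(CCC(=O)O)c3cc2Cl)n1` carries 6-methylpyridin-2-yl in place of pyrimidin-2-yl, with 6-methylpyridin-2-yl in place of pyrimidin-2-yl on a saturated chain carbon bound to an oxygen on an aromatic ring and a saturated chain carbon as the counted difference. Among the compounds with values here, the one measured step, a step that the two limits leave unreadable from compound 1 to compound 2 here, gives no size to carry over. Expected is a step that the limit leaves unreadable from compound 2 to compound 3 with no shift beyond the scatter in this assay and no direction to name. For compound 3 the estimate is 2.5 nm/s with an expected range from 1 nm/s to 6 nm/s and a limit again the likely report.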

Compound 3, apparent permeability: 21 nm/s
The estimate for compound 3 lay 8.4-fold (0.92 log units) below the measured number; the measured number lies above the stated range.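

In this assay, going by these compounds alone, 6-methylpyridin-2-yl at this position is the first change to bring a readable number, with an at least 7.0-fold higher number from compound 2 to compound 3 (0.84 log units; beyond the scatter) and an at least 7.0-fold higher number from compound 1 to compound 3 (0.84 log units; beyond the scatter). The step from compound 1 to compound 2 cannot be read. Compound 3 alone stands off the limit: the limit of < 3 nm/s in this assay, at which 2 of the 3 values shown sit.

The change brings a methyl and one hetero atom fewer in the ring together, and the compounds shown do not separate the two. Unsubstituted pyridin-2-yl at this position would part them, and a 6-ethylpyridin-2-yl would test a longer chain there.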